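This account rests on a few compounds, and the source may have more. Where it says the series, first, only, none or still open, it means among the compounds named here.

Within the data shown here, in a functional assay on A549 cells (Homo sapiens) for inhibition, read by MTT assay, with a stated time of 72 h (a higher number here means a weaker inhibitor, a lower number a stronger inhibitor), the three measured members sit close together. Compound 1 `O=C(CCC(=O)OCCCCCCSc1ccc([N+](=O)[O-])c2nonc12)Nc1ccccc1Cl` gives 2750 nM. Compound 2 `COc1ccccc1NC(=O)CCC(=O)OCCCCCCSc1ccc([N+](=O)[O-])c2nonc12` gives 1870 nM. Compound 3 `O=C(CCC(=O)OCCCCCCSc1ccc([N+](=O)[O-])c2nonc12)Nc1ccc(Br)cc1` gives 3340 nM. Compound 3 carries the highest of the three numbers, but the gaps are small: a 1.2-fold higher number from compound 1 to compound 3 (0.08 log units; within the scatter) and a 1.8-fold higher number from compound 2 to compound 3 (0.25 log units; within the scatter) both stay inside the scatter, as does a 1.5-fold lower number from compound 1 to compound 2 (0.17 log units; within the scatter).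

Compound 4 `COc1ccc(NC(=O)CCC(=O)OCCCCCCSc2ccc([N+](=O)[O-])c3nonc23)cc1` differs from compound 3 by methoxy in place of bromo on an aromatic carbon. Among the measured compounds shown here, two measured steps bear on this change. Exchanging a halogen for methoxy on an aromatic carbon gave a 1.5-fold lower number from compound 1 to compound 2 (0.17 log units; within the scatter), and exchanging a 2-methoxyphenyl for a 4-bromophenyl on the amide nitrogen gave a 1.8-fold higher number from compound 2 to compound 3 (0.25 log units; within the scatter). Both are small, and neither separates the halogen from the methoxy beyond the scatter. No shift beyond the scatter is therefore expected in this assay, with a mild lean toward a lower number, and the step from compound 3 is estimated as a 1.3-fold lower number from compound 3 to compound 4 (0.13 log units; within the scatter). Compound 4 is expected to give 2500 nM, within a range of 1200 nM to 5200 nM.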

Compound 4, half-maximal inhibitory concentration: 6480 nM
Estimate against measurement, compound 4: 2.6-fold (0.41 log units) below; the whole stated range lies below it.
By their numbers in this assay, from the lowest: compounds 2, 1, 3 and 4 (each within the scatter of the next, the first and the last beyond it).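

In this assay, methoxy in place of bromo on an aromatic carbon, para to a large group, gives a step that does not separate the two groups (a 1.9-fold higher number from compound 3 to compound 4 (0.29 log units; within the scatter)). The series now shows its first steps beyond the scatter, and both end at the 4-methoxyphenyl amide: 4-methoxyphenyl in place of 2-methoxyphenyl, a pair that carries the same group on the ring, gives a 3.5-fold higher number from compound 2 to compound 4 (0.54 log units; beyond the scatter) and 4-methoxyphenyl in place of 2-chlorophenyl gives a 2.4-fold higher number from compound 1 to compound 4 (0.37 log units; beyond the scatter) so in this one methoxy pair the place of the group on the ring shifts the number modestly. Nothing available accounts for this shift.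

Going by these compounds, whether the same gap appears with a halogen remains open, since a 2-bromophenyl amide would be needed to pair with compound 3. On these data alone, an amine or a carboxylic acid on that same ring carbon also remains untested against the bromo and methoxy groups.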